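The compounds below may be only part of what the source reports. "The series", "measured", "known", "first", "only" and "open" are said of these compounds alone.

compound 1 `CCOc1ccccc1-n1nncc1CN1C(=O)C2(C(C#N)=C(N)Oc3c(N)cc4nc5ccccc5nc4c32)c2ccccc21`: > 50000 nM
compound 2 `CCc1cccc(CC)c1-n1nncc1CN1C(=O)C2(C(C#N)=C(N)Oc3c(N)cc4nc5ccccc5nc4c32)c2ccccc21`: 37600 nM

In a functional assay on HCT-116 cells (Homo sapiens) for antiproliferative activity, read by MTT assay, with a stated time of 48 h (a higher number here means a weaker inhibitor, a lower number a stronger inhibitor), compound 1 gives only a limit, > 50000 nM (the limit of > 50000 nM in this assay, at which 1 of the 2 values shown sits). Among the measured compounds shown here, compound 2 gives in this assay 37600 nM, the only number among the two values shown. For the measured compounds named here, the one measured step, an at least 1.3-fold lower number from compound 1 to compound 2 (0.12 log units; that floor lies within the scatter), has a floor within the scatter.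

Compound 3 `COc1cc(-n2nncc2CN2C(=O)C3(C(C#N)=C(N)Oc4c(N)cc5nc6ccccc6nc5c43)c3ccccc32)c(OC)cc1Cl` differs from compound 2 by 4-chloro-2,5-dimethoxyphenyl in place of 2,6-diethylphenyl on an aromatic nitrogen. Going by the values given here, the only measured step that bears on this exchange is an at least 1.3-fold lower number from compound 1 to compound 2 (0.12 log units; that floor lies within the scatter), which also swapped the group on this aromatic nitrogen and stayed within the scatter. For compound 3 the expected step is a 1.1-fold higher number from compound 2 to compound 3 (0.03 log units; within the scatter), none beyond the scatter. Compound 3 is therefore estimated at 40000 nM, with a range of 15000 nM to 100000 nM.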

Compound 3, half-maximal inhibitory concentration: > 50000 nM
Compound 3: no number, only a limit; the forecaster's own chance of this, stated with the estimate: 40%; middle value at least 1.2-fold (0.09 log units) from the limit.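

In this assay, compound 3 gives only a limit, as compound 1 does: the limit of > 50000 nM in this assay, at which 2 of the 3 values shown sit. Placing 4-chloro-2,5-dimethoxyphenyl on the aromatic nitrogen gives an at least 1.3-fold higher number from compound 2 to compound 3 (0.12 log units; that floor lies within the scatter), so this exchange adds a third aryl group without a change that can be told from the scatter. The step between the two compounds that give only limits cannot be read.

On these data alone, how far compound 1 and compound 3 lie from compound 2 stays open. So does whether an unsubstituted phenyl, an aminophenyl or a carboxylic acid on this ring would give a clearly lower number.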